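A few compounds are considered here, and "the series" means these few. Any claim that something is new, unique, unknown or untested is made for them only; others in the source may bear on it.

Compound 1 `N#CC1=C(N)N(c2ccc(S(N)(=O)=O)cc2)C2=C(CCCC2)C1c1ccccc1` — 20%
Compound 2 `N#CC1=C(N)N(c2ccc(S(N)(=O)=O)cc2)C2=C(CCCC2)C1c1ccc(O)cc1` — 60%
Compound 3 `N#CC1=C(N)N(c2ccc(S(N)(=O)=O)cc2)C2=C(CCCC2)C1/C=C/c1ccccc1` — 90%

In a functional assay on Ehrlich cells (Mus musculus) for cytotoxicity, read by trypan blue exclusion, with a stated time of 2 h, tested at 50 ug/mL (on this read-out lower numbers stand for a weaker effect and higher numbers for a stronger effect at the one concentration tested), compound 3 gives 90%, the highest of the three numbers. Its nearest neighbour is compound 2 with 60%, a rise a number 30 percentage points higher from compound 2 to compound 3 (beyond the scatter). Compound 1 gives 20%, and the rise a number 70 percentage points higher from compound 1 to compound 3 (beyond the scatter) is the largest in the set. Between the two aryl compounds there is also a rise a number 40 percentage points higher from compound 1 to compound 2 (beyond the scatter).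

Compound 4 `COc1ccccc1C1C(C#N)=C(N)N(c2ccc(S(N)(=O)=O)cc2)C2=C1CCCC2` has not yet been measured. It differs from compound 3 by 2-methoxyphenyl in place of 2-phenylethenyl on a saturated ring carbon. The two steps that bear on this are the ones into compound 3: both put 2-phenylethenyl in the place of a phenyl or 4-hydroxyphenyl group, and both raised the number well beyond the scatter. Compound 4 reverses that kind of change, returning to an aromatic group on the saturated ring carbon, so a fall beyond the scatter is expected in this assay. Within the data shown here, no measured step tells whether 2-methoxyphenyl should lie nearer to compound 1 or to compound 2, so compound 4 is estimated at 40%, in a range from 15% to 70%, meaning an expected step of a number 50 percentage points lower from compound 3 to compound 4 (beyond the scatter).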

Compound 4, a percentage reported as activity, at one concentration (the size of the read-out at that concentration, not a potency): 50%
The estimate for compound 4 lay 10 percentage points below the measured number, within the range that was stated.
By their numbers in this assay, from the lowest: compound 1; then compounds 4 and 2 (each within the scatter of the next); then compound 3.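

In this assay, 2-methoxyphenyl on the saturated ring carbon does not match 2-phenylethenyl, although both groups carry the same count of heavy atoms: the exchange gives a number 40 percentage points lower from compound 3 to compound 4 (beyond the scatter). The aryl group itself also responds to a second kind of oxygen-bearing group, since methoxy in place of hydrogen gives a number 30 percentage points higher from compound 1 to compound 4 (beyond the scatter), so the rise is no longer seen with hydroxy alone. Against 4-hydroxyphenyl, the exchange gives a number 10 percentage points lower from compound 2 to compound 4 (within the scatter), so these two substituted aryl groups cannot be told apart here, and both stay clearly short of compound 3.

There is nothing at hand to explain any of these differences. On these data alone, because compound 2 and compound 4 differ in both the oxygen-bearing group and its place on the aryl ring, the contribution of each remains open, as does how 4-methoxyphenyl, 2-hydroxyphenyl, an aryl group bearing an amine or a carboxylic acid, or the saturated 2-phenylethyl chain would compare with 2-phenylethenyl at this position.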